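A few compounds are considered here, and "the series" means these few. Any claim that something is new, unique, unknown or untested is made for them only; others in the source may bear on it.

Measured in a functional assay on HCT-116 cells (Homo sapiens) for cytotoxicity, read by a luciferase reporter and CellTiter-Glo, with a stated time of 72 h; a lower number here means a stronger inhibitor, a higher number a weaker inhibitor:
Compound 1 `COc1ccc(C2=NN(c3ccccc3Cl)C(c3cccc(Cl)c3)C2)cc1`: 1500 nM
Compound 2 `COc1cccc(C2=NN(c3ccccc3Cl)C(c3cccc(Cl)c3)C2)c1`: "not determined" (no result reported)
Compound 3 `COc1cccc(C2=NN(c3ccccc3Cl)C(c3ccccc3Cl)C2)c1`: 2500 nM

Compound 2 has no number in this assay, so it can be placed only beside its two relatives, whose values lie within the usual scatter of each other. Compound 4 `COc1ccccc1C1=NN(c2ccccc2Cl)C(c2cccc(Cl)c2)C1` has not yet been measured. The change is 2-methoxyphenyl in place of 3-methoxyphenyl on a carbon with a double bond to nitrogen, with the same atoms joined differently.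

Going by the values given here, no measured step shows what this change does, so no shift beyond the scatter is expected in either direction. That expectation takes its level from compound 1 at 1500 nM and compound 3 at 2500 nM. The estimated value for compound 4 is 2500 nM, with an expected range from 1000 nM to 6500 nM.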

Compound 4, half-maximal inhibitory concentration: 1900 nM
Beside the measured number, compound 4's estimate is 1.3-fold (0.12 log units) above it; measured number inside the range.
By their numbers in this assay, from the lowest: compounds 1, 4 and 3 (each within the scatter of the next).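

In this assay, going by these compounds alone, 2-methoxyphenyl in place of 4-methoxyphenyl on the carbon with a double bond to nitrogen gives a 1.3-fold higher number from compound 1 to compound 4 (0.10 log units; within the scatter), the first readable step at this position, and it shows that this change of attachment leaves the number within the scatter. The step from compound 2 to compound 4 cannot be read: compound 2 has no number. Nothing given here accounts for the result. So 3-methoxyphenyl at this position remains unplaced against 2-methoxyphenyl. Also open, as far as these compounds go, is what an amine or a carboxylic acid in place of the methoxy group would do.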